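The source may report more compounds than this note shows. Statements on the series, on what has been measured and on what is new or still open speak of the compounds shown alone.

In a functional assay on HT-29 cells (Homo sapiens) for cytotoxicity, read by MTT assay, with a stated time of 72 h; a lower number here means a stronger inhibitor of growth, a higher number a weaker inhibitor of growth:
compound 1 `C[Se]/C(=N\C(=O)c1cccs1)NC(=O)c1cccs1` gives 0.34 nM
compound 2 `O=C(/N=C(/NC(=O)c1cccs1)[Se]Cc1ccccc1)c1cccs1` gives 55100 nM
compound 3 `O=C(/N=C(/NC(=O)c1csc([N+](=O)[O-])c1)[Se]Cc1ccccc1)c1csc([N+](=O)[O-])c1` gives 9250 nM

Compound 2 and compound 1 differ in one place, (hydrogen in place of phenyl on a saturated chain carbon bound to a selenium atom), and that single change gives a 160000-fold lower number from compound 2 to compound 1 (5.21 log units; beyond the scatter). Within the data shown here, compound 3 stands on a different core from compound 2; the difference between the two cores is not broken down here, and the two values show only that compound 3 gives the lower number of the pair.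

Compound 4 `C[Se]/C(=N\C(=O)c1csc([N+](=O)[O-])c1)NC(=O)c1csc([N+](=O)[O-])c1` is not yet measured. It repeats on compound 3 the change seen before: hydrogen in place of phenyl on a saturated chain carbon bound to a selenium atom, the same change at the same place. On these data alone, the step from compound 3 to compound 4 in this assay is therefore expected to be large, because the same change produced a 160000-fold lower number from compound 2 to compound 1 (5.21 log units; beyond the scatter); whether it carries over fully on the other core is untested, so part of it is discounted. The expected step is a 19000-fold lower number from compound 3 to compound 4 (4.27 log units; beyond the scatter). Compound 4 is estimated at 0.5 nM, between 0.03 nM and 10 nM.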

Compound 4, concentration for 50% growth inhibition: 0.63 nM
The estimate for compound 4 lay 1.3-fold (0.10 log units) below the measured number, and the stated range covers the measured number.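

In this assay the change from benzyl to methyl, on a saturated chain carbon bound to a selenium atom, gives a 15000-fold lower number from compound 3 to compound 4 (4.17 log units; beyond the scatter) on the second core, so the direction and the large size of the step carry over. The size does not carry over in full: the same change on two cores in this assay, a 160000-fold lower number (5.21 log units; beyond the scatter) from compound 2 to compound 1 and a 15000-fold lower number (4.17 log units; beyond the scatter) from compound 3 to compound 4, 11-fold (1.04 log units) apart, beyond the scatter of two such steps. With one matched pair on each of two cores, this shows no rule for other cores and gives no reason for the gap between the two steps.

Still open, on these data alone, is whether an ethyl group or a longer chain on the selenium atom keeps the low numbers seen with methyl. As far as these compounds go, an amine or a carboxylic acid at the end of such a chain is equally open.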